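Antiproliferative series on the shared amide core: step to compound 4

This account rests on a few compounds, and the source may have more. Where it says the series, first, only, none or still open, it means among the compounds named here.

Measured so far:
- compound 1, `CCN1CCN(c2cc(C)c3cc(NC(=O)c4ccc[nH]4)ccc3n2)CC1`: 13200 nM
- compound 2, `Cc1cc(N2CCCC2)nc2ccc(NC(=O)c3ccc(Cl)c(Cl)c3)cc12`: 43400 nM
- compound 3, `CCN1CCN(c2cc(C)c3cc(NC(=O)c4cc(Cl)cc(Cl)c4)ccc3n2)CC1`: 2660 nM

All three compounds were tested in a functional assay on SK-BR-3 cells (Homo sapiens) for antiproliferative activity, read by MTT assay, with a stated time of 72 h; on this read-out higher numbers stand for weaker inhibition and lower numbers for stronger inhibition. Compound 1 holds the second highest of the three numbers; compound 2 sits a step away on the weaker side, while compound 3 is the strongest of the three, since its steps to the others are beyond the scatter.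

Compound 4, `CCN1CCN(c2cc(C)c3cc(NC(=O)c4cc5ccccc5[nH]4)ccc3n2)CC1`, has not yet been measured. It differs from compound 1 in one place: 1H-indol-2-yl in place of 1H-pyrrol-2-yl on a carbonyl carbon. Going by the values given here, the only measured step that starts from compound 1 is a 5.0-fold lower number from compound 1 to compound 3 (0.70 log units; beyond the scatter), where the 1H-pyrrol-2-yl was also exchanged for a larger aromatic group on the same carbonyl carbon. Among the compounds with values here, no measured pair shows the 1H-indol-2-yl itself, and compound 2 differs from compound 1 in more than one place, so its value bears only indirectly. On this basis a lowering of the number beyond the scatter is expected for compound 4, smaller than the step to compound 3 because a 5.0-fold lower number from compound 1 to compound 3 (0.70 log units; beyond the scatter) involved a differently substituted group. The estimated value of compound 4 in this assay is 5000 nM, with a range from 1500 nM to 16000 nM, an expected step of a 2.6-fold lower number from compound 1 to compound 4 (0.42 log units; beyond the scatter).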

Compound 4, half-maximal inhibitory concentration: 2550 nM
Beside the measured number, compound 4's estimate is 2.0-fold (0.29 log units) above it; the range from low to high includes it.
By their numbers in this assay, from the lowest: compounds 4 and 3 (each within the scatter of the next); then compound 1; then compound 2.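

In this assay, 1H-indol-2-yl in place of 1H-pyrrol-2-yl on the carbonyl carbon gives a 5.2-fold lower number from compound 1 to compound 4 (0.71 log units; beyond the scatter) and so provides a second lowering of the number at this place, this time with a group that has the same count of hydrogen-bond donors as the one it replaces. The exchange of 3,5-dichlorophenyl for 1H-indol-2-yl gives a 1.0-fold lower number from compound 3 to compound 4 (0.02 log units; within the scatter) and therefore separates these two larger aromatic groups by nothing that can be read in this assay. No measurement shown accounts for either result.

Still open, as far as these compounds go, is whether the hydrogen on the ring nitrogen of the 1H-indol-2-yl matters, which a methyl group on that nitrogen would test. Also open, from the compounds shown here alone, is how a saturated ring such as cyclohexyl, or an amine or carboxylic acid on the aromatic group, would fare on this carbonyl carbon.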